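The source may report more compounds than this note shows. Statements on the series, on what has been measured and on what is new or still open speak of the compounds shown alone.

Compound 2 `Cc1ccc(S(=O)(=O)N2CCC(N3CCC(C)CC3)CC2)cc1C` gives 24 nM in a functional assay on DLD-1 cells (Homo sapiens) for antiproliferative activity, read by CellTiter-Glo, with a stated time of 72 h; a higher number here means a weaker inhibitor, a lower number a stronger inhibitor. Compound 1 `CC1CCN(C2CCN(S(=O)(=O)c3cccnc3Cl)CC2)CC1` gives > 5000 nM in this assay, which is a limit of the assay and not a number.

In this assay compound 2 thus holds the only number shown, the other value being a limit. Compound 3 `CC1CCN(C2CCN(S(=O)(=O)c3nccn3C)CC2)CC1` differs from compound 2 in one place: 1-methyl-1H-imidazol-2-yl in place of 3,4-dimethylphenyl on a sulfonyl sulfur. Among the measured compounds shown here, one measured step bears on it: an at least 200-fold lower number from compound 1 to compound 2 (2.31 log units; beyond the scatter), where a six-membered ring with hetero atoms gave way to the six-membered carbon ring. Compound 3 moves back towards a hetero-atom ring, so a large weakening is expected; the expected step is a 63-fold higher number from compound 2 to compound 3 (1.80 log units; beyond the scatter). Compound 3 is therefore estimated at 1500 nM, between 200 nM and 8000 nM.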

Compound 3, half-maximal inhibitory concentration: > 5000 nM
Compound 3 was reported as a limit; the forecaster's own chance of this, stated with the estimate: 35%; at least 3.3-fold (0.52 log units) between middle value and limit.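

With 1-methyl-1H-imidazol-2-yl in place of 3,4-dimethylphenyl on the sulfonyl sulfur, this assay shows an at least 200-fold higher number from compound 2 to compound 3 (2.31 log units; beyond the scatter). Of the three compounds shown, only compound 2, with its aromatic ring of carbon only, keeps a number, so a five-membered aromatic ring with 2 hetero atoms fails here just as the 2-chloropyridin-3-yl of compound 1 does. The step from compound 1 to compound 3 cannot be read, and the full size of the loss stays unknown because these values are limits: the limit of > 5000 nM in this assay, at which 2 of the 3 values shown sit.

Still open, from the compounds shown here alone, is whether an unsubstituted phenyl ring on the same sulfur would hold the activity of compound 2. The same question stands for a 4-methoxyphenyl group.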